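Carboxy on a Piperidone Amide Chain: Expected Cytotoxicity

The source may hold more compounds than are shown below. What is called first, only, known or untested is meant among the compounds shown, and "the series" means these compounds.

Measured compounds:
compound 1 `CCN1C/C(=C\c2ccc(OC)c(OC)c2)C(=O)/C(=C/c2ccc(OC)c(OC)c2)C1`: 12000 nM
compound 2 `CCC(=O)N1C/C(=C\c2cc(OC)c(OC)c(OC)c2)C(=O)/C(=C/c2cc(OC)c(OC)c(OC)c2)C1`: 4400 nM
compound 3 `COc1ccc(/C=C2\CNC/C(=C\c3ccc(OC)c(OC)c3)C2=O)cc1OC`: 16700 nM

Of the compounds shown here, three sharing one core have been tested in a functional assay on NCI-H1650 cells (Homo sapiens) for cytotoxicity, read by MTT assay, with a stated time of 72 h; on this read-out lower numbers stand for stronger inhibition and higher numbers for weaker inhibition. Compound 2 `CCC(=O)N1C/C(=C\c2cc(OC)c(OC)c(OC)c2)C(=O)/C(=C/c2cc(OC)c(OC)c(OC)c2)C1` gives the lowest number of the three, 4400 nM. Its nearest neighbour is compound 1, whose value in this assay is 12000 nM; the gap to compound 3, which gives 16700 nM, is larger, and both gaps lie beyond the scatter.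

Among the compounds with values here, the one step measured between single-change pairs is a 1.4-fold higher number from compound 1 to compound 3 (0.14 log units; within the scatter). It sits on the ring nitrogen of the core and shows that swapping what that nitrogen carries can leave the read-out essentially unchanged.

Compound 4 `COc1cc(/C=C2\CN(C(=O)CCC(=O)O)C/C(=C\c3cc(OC)c(OC)c(OC)c3)C2=O)cc(OC)c1OC` has not yet been measured. It differs from compound 2 in one place: carboxy in place of hydrogen on a saturated chain carbon, two bonds along the chain from a carbonyl carbon. Within the data shown here, this change lies on the amide chain attached to the same ring nitrogen, so the step from compound 1 to compound 3 is the only measured step that bears on it, and that step stayed within the scatter. Among the measured compounds shown here, no measured step concerns a carboxy group itself.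

Because a 1.4-fold higher number from compound 1 to compound 3 (0.14 log units; within the scatter) was flat, the expectation is that compound 4 shows a step of a 1.3-fold higher number from compound 2 to compound 4 (0.10 log units; within the scatter) in this assay, not beyond the scatter. Compound 4 is therefore estimated at 5500 nM, with a range from 2000 nM to 16000 nM.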

Compound 4, half-maximal inhibitory concentration: > 60000 nM
Compound 4: a limit, no number; the forecaster's own chance of this, stated with the estimate: 5%; middle value at least 10-fold (1.03 log units) from the limit.
By their numbers in this assay, from the lowest: compound 2; then compounds 1 and 3 (each within the scatter of the next). At a limit, above all of these: compound 4.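

For compound 4 the entry in this assay is a limit of the assay and not a number: the limit of > 60000 nM in this assay, at which 1 of the 4 values shown sits. The true size of the step is therefore unknown, but what can be read is an at least 13-fold higher number from compound 2 to compound 4 (1.13 log units; beyond the scatter), so this one change, from propanoyl to (2-carboxyethyl)carbonyl, moves the read-out far beyond the scatter. Within the data shown here, the only earlier step on the ring nitrogen, a 1.4-fold higher number from compound 1 to compound 3 (0.14 log units; within the scatter), had suggested that what this nitrogen carries may matter little, whereas the new result shows that a carboxy on a saturated chain carbon, two bonds along the chain from a carbonyl carbon, is not tolerated in the same way.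

The compounds shown do not tell whether the weaker result belongs to the carboxylic acid itself or to any larger group at this place. A methyl ester, a primary amide, an amine or a longer chain ending in a carboxylic acid at the same carbon would help separate these possibilities, and a value for any of them that is a true number would also show how steep the change is.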